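The source may hold more compounds than are shown below. What is called first, only, known or untested is meant among the compounds shown, and "the series" means these compounds.

The measured compounds are compound 1, `[N-]=[N+]=NCCOCCOCCO[Si]1(OCCOCCOCCN=[N+]=[N-])n2c3c4ccccc4c2/N=C2\N=C(/N=c4/c5ccccc5/c(n41)=N/C1=N/C(=N\3)c3ccccc31)c1ccccc12`, with 8.6 nM in a functional assay on HT-29 cells (Homo sapiens) for cytotoxicity, read by MTT assay, with a stated time of 2 h (a higher number here means a weaker inhibitor, a lower number a stronger inhibitor), and compound 2, `[N-]=[N+]=NCCOCCO[Si]1(OCCOCCO)n2c3c4ccccc4c2/N=C2\N=C(/N=c4/c5ccccc5/c(n41)=N/C1=N/C(=N\3)c3ccccc31)c1ccccc12`, with 3.2 nM in this assay.

Compound 2 holds the lower of the two numbers in this assay; the nearest value, that of compound 1, stands higher by a margin beyond the usual scatter. The two compounds differ in more than one place, so their values are only compared, not read as a step of one change.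

The next compound is compound 3, `[N-]=[N+]=NCCOCCO[Si]1(OCCOCCN=[N+]=[N-])n2c3c4ccccc4c2/N=C2\N=C(/N=c4/c5ccccc5/c(n41)=N/C1=N/C(=N\3)c3ccccc31)c1ccccc12`. It differs from compound 2 in one place: azido in place of hydroxy on a saturated chain carbon, two bonds along the chain from an oxygen on a saturated carbon. Among the compounds with values here, the gap between compound 1 and compound 2 in this assay does not isolate this change, so there is no measured step on which to rest a firm expectation. Given that compound 2 gives 3.2 nM in this assay, a small rise is expected, of a size that would stay at the edge of the scatter, amounting to a 1.6-fold higher number from compound 2 to compound 3 (0.19 log units; within the scatter). Compound 3 is therefore estimated at 5 nM in this assay, within a range of 2 nM to 13 nM.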

Compound 3, half-maximal inhibitory concentration: 12 nM
For compound 3 the middle estimate is 2.4-fold (0.38 log units) below the measured one; low and high end bracket the measured number.
By their numbers in this assay, from the lowest: compound 2; then compounds 1 and 3 (each within the scatter of the next).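

Azido in place of hydroxy on a saturated chain carbon, two bonds along the chain from an oxygen on a saturated carbon, is the first single change that can be read in this assay, and it gives a 3.8-fold higher number from compound 2 to compound 3 (0.57 log units; beyond the scatter). The step is modest but lies beyond the scatter, so this position is not indifferent to the group it carries, and in this pair the hydroxy goes with the lower number and so with the stronger inhibitor. Nothing measured here gives a reason for this step.

As far as these compounds go, the reading rests on this one pair, with the other chain of the molecule left as 2-azidoethoxy-bearing in both compounds, so it remains open whether the same swap would give a step of similar size on a longer chain. From the compounds shown here alone, it also remains open where an amine, a carboxylic acid or a methoxy group at this same place would fall relative to the hydroxy of compound 2 and the azido of compound 3.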